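This account rests on a few compounds, and the source may have more. Where it says the series, first, only, none or still open, it means among the compounds named here.

Working notes on the series in a functional assay on MOLT-4 cells (Homo sapiens) for antiproliferative activity, read by MTT assay, with a stated time of 3 days; on this read-out lower numbers stand for stronger inhibition and higher numbers for weaker inhibition. Compound 1 `CCCCCCCCC#Cc1cn(C/C=C/CN2C(=O)c3ccccc3C2=O)c(=O)[nH]c1=O` gives in this assay only a limit of the assay, > 250000 nM, and this limit is the one described as the limit of > 250000 nM in this assay, at which 1 of the 3 values shown sits. Compound 2 `CCCCc1ccc(C#Cc2cn(C/C=C/CN3C(=O)c4ccccc4C3=O)c(=O)[nH]c2=O)cc1` gives in this assay 29000 nM. Within the data shown here, the single step between compounds that differ in one place is an at least 8.6-fold lower number from compound 1 to compound 2 (0.93 log units; beyond the scatter), a change of the group on the triple-bonded carbon. Compound 3 `O=C1c2ccccc2C(=O)N1C/C=C\Cn1cc(C#CCCc2ccccc2)c(=O)[nH]c1=O` gives in this assay 146000 nM, which is the highest of the two numbers shown; the nearest number is that of compound 2, and the gap between them lies beyond the scatter.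

Compound 4 `O=C1c2ccccc2C(=O)N1C/C=C/Cn1cc(C#CCCc2ccccc2)c(=O)[nH]c1=O` has not yet been measured. Its difference from compound 3 is the two compounds have the same atoms and bonds and differ only in configuration as drawn: 1 of 1 stereo elements differ; a double bond is drawn Z in compound 3 and E in compound 4. Among the measured compounds shown here, no measured step concerns the geometry of this double bond: the step from compound 1 to compound 2 alters the group on the triple-bonded carbon, and compound 1 and compound 2 differ from compound 3 in more than one place, so their values give no direct step toward compound 4. The expected change for the step from compound 3 to compound 4 is therefore set at a 1.2-fold lower number from compound 3 to compound 4 (0.09 log units; within the scatter), none beyond the scatter, with wide uncertainty. Compound 4 is estimated in this assay at 120000 nM, within 30000 nM to 400000 nM.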

Compound 4, half-maximal inhibitory concentration: 39000 nM
Compound 4: middle estimate off by 3.1-fold (0.49 log units), on the high side, within the range that was stated.
By their numbers in this assay, from the lowest: compounds 2 and 4 (each within the scatter of the next); then compound 3. At a limit, above all of these: compound 1.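

In this assay the change from a Z to an E double bond gives a gap (a 3.7-fold lower number from compound 3 to compound 4 (0.57 log units; beyond the scatter)), the only read on this geometry among the compounds shown, and that gap can be set on the double bond alone because nothing else changes: the fact that compounds 3 and 4 differ only in the configuration as drawn. With the E double bond in place, phenethyl in place of 4-butylphenyl on a triple-bonded carbon gives no separation in this assay (a 1.3-fold higher number from compound 2 to compound 4 (0.13 log units; within the scatter)), so these two groups are not told apart here. The step from the octyl compound to the phenethyl compound (an at least 6.4-fold lower number from compound 1 to compound 4 (0.80 log units; beyond the scatter)) is only a bound, as compound 1 gives a limit and not a number: the limit of > 250000 nM in this assay, at which 1 of the 4 values shown sits.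

Open, from the compounds shown here alone, is whether the gap between the Z and E forms holds with 4-butylphenyl or octyl on the triple-bonded carbon, since the comparison rests on the phenethyl pair alone. Also open, going by these compounds, is what an amine or a carboxylic acid would give in place of the phenyl of the phenethyl group, and what a longer chain would give on the triple-bonded carbon.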